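The compounds below may be only part of what the source reports. "The series", "measured", "known", "first", "only" and "open" are said of these compounds alone.

In a functional assay on B16-F10 cells (Mus musculus) for inhibition, read by colorimetric assay and MTT assay, with a stated time of 72 h (on this read-out higher numbers stand for weaker inhibition and lower numbers for stronger inhibition), three compounds have been measured so far. Compound 1 `Cc1ccc(C(=O)NNC(=S)Nc2csc(-c3ccccc3)c2)cc1` gives 24000 nM. Compound 2 `COc1ccc(C(=O)NNC(=S)Nc2csc(-c3ccccc3)c2)cc1`, which carries the change (methoxy in place of methyl on an aromatic carbon), gives 33000 nM. The step of a 1.4-fold higher number from compound 1 to compound 2 (0.14 log units; within the scatter) is therefore small enough that the two numbers cannot be told apart with confidence. Compound 3 `Cc1ccc(-c2nnc(Nc3csc(-c4ccccc4)c3)s2)cc1` rests on a different core and gives 4000 nM; its number is the lowest of the three, and both compound 1 and compound 2 stand beyond the scatter from it, so on this read-out compound 3 is the strongest inhibitor among the measured compounds. How the core of compound 3 differs from the core of compound 1 is not broken down here.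

Compound 4 `COc1ccc(-c2nnc(Nc3csc(-c4ccccc4)c3)s2)cc1` has not yet been measured. Among the measured compounds shown here, it stands to compound 3 as compound 2 stands to compound 1: the change methoxy in place of methyl on an aromatic carbon is the same change, made at the same kind of place, as the one from compound 1 to compound 2. Since that earlier change produced only a 1.4-fold higher number from compound 1 to compound 2 (0.14 log units; within the scatter), a step that stays within the scatter, a similarly small step is expected here, and the estimate is a 1.3-fold higher number from compound 3 to compound 4 (0.10 log units; within the scatter). On that basis compound 4 is expected to give about 5000 nM in this assay, with the likely range running from 2500 nM to 12000 nM, resting on the value of compound 3 4000 nM and on the small size of the earlier step.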

Compound 4, half-maximal inhibitory concentration: 6000 nM
For compound 4 the middle estimate is 1.2-fold (0.08 log units) below the measured one; measured number inside the range.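

The swap of methyl for methoxy on the aromatic carbon, para to a large group, reads as a 1.5-fold higher number from compound 3 to compound 4 (0.18 log units; within the scatter) in this assay, so on this second core the two compounds cannot be told apart either. Set beside each other, the steps on the two cores agree, and the change carries over from one core to the other as a step within the scatter each time: the same change on two cores in this assay, a 1.4-fold higher number (0.14 log units; within the scatter) from compound 1 to compound 2 and a 1.5-fold higher number (0.18 log units; within the scatter) from compound 3 to compound 4, 1.1-fold (0.04 log units) apart, within the scatter of two such steps This does not show that methyl and methoxy are truly equivalent in this series, because two pairs in a single assay cannot settle that, and steps this small give no reliable direction; nor does it say anything about why the swap makes so little difference, or whether the agreement would hold on a third core.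

The compounds shown leave open whether a group of another kind at this same place, such as an amine, a carboxylic acid or a longer chain, would give a step beyond the scatter. They also leave open whether such a group would give steps of matching size on both cores, as methoxy does here.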